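The source may hold more compounds than are shown below. What is called first, only, known or untested is meant among the compounds shown, and "the series" means these compounds.

Measured compounds in the series:

- compound 1, `COc1cc2c(Oc3ccc(NC(=O)c4cn(-c5ccccc5Cl)nn4)cc3F)ccnc2cc1OCCCN1CCCC1`: 330 nM
- compound 2, `COc1cc2c(Oc3ccc(NC(=O)c4cn(-c5ccc(Br)cc5)nn4)cc3F)ccnc2cc1OCCCN1CCCC1`: 370 nM

Both were run in a functional assay on A549 cells (Homo sapiens) for cytotoxicity, read by MTT assay, with a stated time of 72 h; a lower number here means a stronger inhibitor, a higher number a weaker inhibitor. Compound 2 holds the higher of the two numbers, though the step of a 1.1-fold higher number from compound 1 to compound 2 (0.05 log units; within the scatter) is within the scatter, so the two are not distinguished. Compound 3, `COc1cc2c(Oc3ccc(NC(=O)c4cn(-c5c(C)cccc5C)nn4)cc3F)ccnc2cc1OCCCN1CCCC1`, is not yet measured; it differs from compound 2 by 2,6-dimethylphenyl in place of 4-bromophenyl on an aromatic nitrogen. Among the compounds with values here, the only measured step that bears on this position is the one from compound 1 to compound 2, which exchanged one substituted phenyl on the same aromatic nitrogen for another and moved the number within the scatter. Within the data shown here, no measured step covers a phenyl carrying two methyl groups, so the expectation rests on that single comparison. The step expected here is a 1.1-fold lower number from compound 2 to compound 3 (0.02 log units; within the scatter). For compound 3 the estimate in this assay is 350 nM, with a range from 150 nM to 900 nM.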

Compound 3, half-maximal inhibitory concentration: 1240 nM
Estimate against measurement, compound 3: 3.5-fold (0.55 log units) below; the measured number lies above the stated range.
By their numbers in this assay, from the lowest: compounds 1 and 2 (each within the scatter of the next); then compound 3.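

In this assay, the aryl group on this aromatic nitrogen does affect the number: 2,6-dimethylphenyl gives a 3.4-fold higher number from compound 2 to compound 3 (0.53 log units; beyond the scatter) and a 3.8-fold higher number from compound 1 to compound 3 (0.57 log units; beyond the scatter), both beyond the scatter, whereas the earlier exchange between 4-bromophenyl and 2-chlorophenyl was not. Compound 3 is therefore weaker than both compound 1 and compound 2, which remain undistinguished from each other. No measurement available here accounts for this difference.

The compounds shown leave open whether the shift follows from the presence of two methyl groups, from methyl in place of halogen, or from the substitution pattern on the phenyl. Also open, as far as these compounds go, is how this position responds to an unsubstituted phenyl, a phenyl with a single methyl group, or a phenyl carrying an amine or a carboxylic acid.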